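Working notes on the step from compound 3 to compound 4

The source may hold more compounds than are shown below. What is called first, only, known or untested is meant among the compounds shown, and "the series" means these compounds.

Compound 3 `C=CC(=O)Nc1cccc(NC(=O)CSc2nc(Nc3ccccc3)c3ccccc3n2)c1` gives 8120 nM in a functional assay on NCI-H1975 cells (Homo sapiens) for inhibition, read by MTT assay, with a stated time of 72 h; on this read-out lower numbers stand for stronger inhibition and higher numbers for weaker inhibition. Among the three measured members it stands second highest of the three numbers. Its nearest neighbour is compound 1 `O=C(CSc1nc(Nc2ccccc2)c2ccccc2n1)Nc1cccc(F)c1`, which gives 6790 nM, the gap being a 1.2-fold higher number from compound 1 to compound 3 (0.08 log units; within the scatter). The furthest is compound 2 `O=C(CSc1nc(Nc2ccccc2)c2ccccc2n1)Nc1cccc([N+](=O)[O-])c1`, which gives 17900 nM, with a 2.2-fold lower number from compound 2 to compound 3 (0.34 log units; beyond the scatter). The remaining measured step is a 2.6-fold higher number from compound 1 to compound 2 (0.42 log units; beyond the scatter).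

Compound 4 `C=CC(=O)Nc1cccc(NC(=O)CSc2nc(Nc3ccc(F)c(Cl)c3)c3ccccc3n2)c1` differs from compound 3 at the other end of the shared core: 3-chloro-4-fluorophenyl in place of phenyl on a nitrogen on an aromatic ring. Among the measured compounds shown here, none of the measured steps touches this position. For the measured compounds named here, all three vary a substituent on an aromatic carbon elsewhere in the molecule, while the anilino group is held constant throughout, so there is no direct precedent for the size or direction of this change in this assay. The three measured numbers span only a modest range overall. In the absence of any bearing step, the expected outcome is no step beyond the scatter, and the estimated step is a 1.2-fold lower number from compound 3 to compound 4 (0.10 log units; within the scatter). Compound 4 is accordingly estimated at 6500 nM, with an expected range from 2500 nM to 18000 nM.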

Compound 4, half-maximal inhibitory concentration: > 50000 nM
Compound 4 was reported as a limit; the forecaster's own chance of this, stated with the estimate: 5%; middle value at least 7.6-fold (0.88 log units) away from the limit.
By their numbers in this assay, from the lowest: compounds 1 and 3 (each within the scatter of the next); then compound 2. At a limit, above all of these: compound 4.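

The anilino position, held constant across compounds 1 to 3, responds strongly in this assay: 3-chloro-4-fluorophenyl in place of phenyl on a nitrogen on an aromatic ring gives an at least 6.1-fold higher number from compound 3 to compound 4 (0.78 log units; beyond the scatter). Among the compounds shown here, this is the only step at this position, and it exceeds the largest step among the substituent changes elsewhere in the molecule, which is a 2.6-fold higher number from compound 1 to compound 2 (0.42 log units; beyond the scatter); the series is therefore not insensitive to change at this nitrogen, as the earlier compounds alone might have suggested. Compound 4 gives > 50000 nM, which is a limit and not a number, so the step fixes only a minimum size and the true distance from compound 3 stays unknown: the limit of > 50000 nM in this assay, at which 1 of the 4 values shown sits.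

The compounds shown do not separate the chloro from the fluoro, so it remains open whether 3-chlorophenyl or 4-fluorophenyl alone would carry the same loss, or whether a methyl or methoxy on that phenyl would be tolerated. From the compounds shown here alone, it is also open whether the same replacement would behave alike with the fluoro or nitro substituent of compound 1 or compound 2 in place of the (vinylcarbonyl)amino group.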